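Compound 1 to compound 3: an unmeasured side-chain swap

The compounds below may be only part of what the source reports. "The series", "measured", "known", "first", "only" and "open" are said of these compounds alone.

In a functional assay on PC-3 cells (Homo sapiens) for inhibition, read by MTT assay, with a stated time of 24 h (on this read-out higher numbers stand for weaker inhibition and lower numbers for stronger inhibition), compound 1 (`CCOC1c2cc(OCc3cc(C)cc(C)c3)c(OCc3cc(C)cc(C)c3)cc2CCN1C(=O)OC(C)(C)C`) reads > 20000 nM. That value is a limit of the assay and not a number, so the starting point has no exact position. Compound 2 (`CCC[C@@H]1C[C@@H](O)/C=C\C(CC)[C@H]2c3cc(OCc4ccccc4)c(OCc4ccccc4)cc3CCN12`) offers no comparison, with the entry "not determined" (no result reported). Among the compounds with values here, the series therefore contains no measured step.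

Compound 3 (`C/C=C/C(=O)CC1c2cc(OCc3cc(C)cc(C)c3)c(OCc3cc(C)cc(C)c3)cc2CCN1C(=O)OC(C)(C)C`) keeps the core of compound 1 and carries ((prop-1-en-1-yl)carbonyl)methyl in place of ethoxy on a saturated ring carbon. Within the data shown here, with no step to calibrate against, only a moderate shift toward stronger inhibition in this assay is expected, and another limit reading remains quite possible. The estimated change is an at least 2.0-fold lower number from compound 1 to compound 3 (0.30 log units; that floor lies within the scatter). For compound 3, the expected value is 10000 nM, within an estimated range of 2500 nM to 30000 nM.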

Compound 3, half-maximal inhibitory concentration: > 20000 nM
Compound 3: only a limit was reported (the forecaster's own chance of this, stated with the estimate: 45%); at least 2.0-fold (0.30 log units) between middle value and limit.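

In this assay no step can be read from compound 1 to compound 3, since both entries are limits of the assay and not numbers: the limit of > 20000 nM in this assay, at which 2 of the 3 values shown sit. The compounds shown leave open how far each compound lies past that limit, and whether ((prop-1-en-1-yl)carbonyl)methyl in place of ethoxy changes inhibition at all.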